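A few compounds are considered here, and "the series" means these few. Any claim that something is new, unique, unknown or untested is made for them only; others in the source may bear on it.

Working notes on the series. Among the measured compounds shown here, in an ADME assay on the whole organism (Macaca fascicularis) for pharmacokinetics, read by LC-MS, using cassette dosing, at a dose of 1 mg/kg by the oral route (a lower number here means less compound in the circulation, a higher number more compound in the circulation at the dose given), compound 1 `CCCCN(c1nc2c(NS(C)(=O)=O)cccc2o1)[C@H](C)c1ccc(-c2ccccc2-c2nnn[nH]2)cc1` gives 49.9 nM, which puts it second highest of the three numbers measured so far. Compound 3 `CCCCN(c1nc2c(C(=O)NS(C)(=O)=O)cccc2o1)[C@H](C)c1ccc(-c2ccccc2-c2nnn[nH]2)cc1` gives 40.4 nM in this assay, and the step of a 1.2-fold lower number from compound 1 to compound 3 (0.09 log units; within the scatter) stays within the scatter. Compound 2 `CCCCN(c1nc2c(C(=O)O)cccc2o1)[C@H](C)c1ccc(-c2cc(Cl)ccc2-c2nc(=O)o[nH]2)cc1` gives 677 nM in this assay, the highest of the three and beyond the scatter from compound 1; compound 2 differs from compound 1 in several places at once, so its value shows no single change.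

Compound 4 `CCCCN(c1nc2c(-c3ccccn3)cccc2o1)[C@H](C)c1ccc(-c2ccccc2-c2nnn[nH]2)cc1` awaits measurement in this assay. The change from compound 1 is pyridin-2-yl in place of methanesulfonamido on an aromatic carbon. For the measured compounds named here, the one measured step at the same position, from compound 1 to compound 3, swapped one sulfonyl-bearing group for another and moved nothing beyond the scatter; no measured pair covers the entry of an aromatic ring in place of the sulfonamide. The expectation therefore rests on that single flat step: a step of a 1.4-fold higher number from compound 1 to compound 4 (0.15 log units; within the scatter) is expected, with no direction claimed beyond the scatter. Compound 4 is estimated at 70 nM in this assay, within a range of 20 nM to 250 nM.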

Compound 4, maximal plasma concentration: 124 nM
Compound 4: the middle estimate sits 1.8-fold (0.25 log units) below what was measured; low and high end bracket the measured number.
By their numbers in this assay, from the lowest: compounds 3 and 1 (each within the scatter of the next); then compound 4; then compound 2.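

Among the compounds shown here, the position is not indifferent to what it carries: with pyridin-2-yl in place of methanesulfonamido on an aromatic carbon, this assay gives a 2.5-fold higher number from compound 1 to compound 4 (0.40 log units; beyond the scatter), the first change in one place in this set to pass the scatter. The same group in place of (methylsulfonyl)carbamoyl gives a 3.1-fold higher number from compound 3 to compound 4 (0.49 log units; beyond the scatter), so both sulfonyl-bearing groups, which could not be told apart from each other, stand modestly beneath the pyridin-2-yl compound. Nothing measured here bears on what lies behind this rise.

The compounds shown leave open whether the step belongs to the aromatic ring as such or to its ring nitrogen, which a plain phenyl group at this place on the core of compound 1 would separate. Also open, as far as these compounds go, is what a carboxylic acid alone does at this place, since compound 2 carries one together with changes elsewhere in the molecule.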